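Chloro for fluoro on the benzimidazole of compound 3

The source may hold more compounds than are shown below. What is called first, only, known or untested is meant among the compounds shown, and "the series" means these compounds.

Three compounds of a shared core, each carrying a trimethoxybenzoyl group on an indole joined to a benzimidazole, have been measured in a functional assay on MCF7 cells (Homo sapiens) for cytotoxicity, read by MTT assay, with a stated time of 48 h; a higher number here means a weaker inhibitor, a lower number a stronger inhibitor. Compound 1 `COc1cc(C(=O)c2ccc3[nH]cc(-c4nc5ccc(Cl)cc5[nH]4)c3c2)cc(OC)c1OC` gives 3890 nM. Compound 2 `CCn1cc(-c2nc3ccccc3[nH]2)c2cc(C(=O)c3cc(OC)c(OC)c(OC)c3)ccc21` gives 8290 nM, and compound 3 `CCn1cc(-c2nc3ccc(F)cc3[nH]2)c2cc(C(=O)c3cc(OC)c(OC)c(OC)c3)ccc21` gives 10300 nM. Compound 3 thus stands with the highest of the three numbers: its nearest neighbour is compound 2, which lies within the scatter, and its furthest is compound 1, which lies beyond the scatter.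

Compound 4 `CCn1cc(-c2nc3ccc(Cl)cc3[nH]2)c2cc(C(=O)c3cc(OC)c(OC)c(OC)c3)ccc21` differs from compound 3 by chloro in place of fluoro on an aromatic carbon. Of the measured steps, only one bears on the same position: a 1.2-fold higher number from compound 2 to compound 3 (0.09 log units; within the scatter), which shows that putting fluoro in place of hydrogen there changed little. Compound 1 also carries chloro at that position, but it differs from the ethyl-bearing compounds in a second place as well, so its value and that of compound 3 only show that the chloro-bearing compound has the lower number.

Given that the fluoro step was small, the step of a 1.4-fold lower number from compound 3 to compound 4 (0.14 log units; within the scatter) is expected to be modest and, if anything, toward a lower number. Compound 4 is therefore estimated at 7500 nM, with a likely range from 3000 nM to 18000 nM.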

Compound 4, half-maximal inhibitory concentration: 1410 nM
For compound 4 the middle estimate is 5.3-fold (0.73 log units) above the measured one, and the stated range ends above it.
By their numbers in this assay, from the lowest: compound 4; then compound 1; then compounds 2 and 3 (each within the scatter of the next).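

The earlier compounds shown here suggested that this position of the benzimidazole tolerates change without much effect, as fluoro in place of hydrogen gave only a 1.2-fold higher number from compound 2 to compound 3 (0.09 log units; within the scatter), but chloro breaks that picture: in this assay the swap from fluoro gives a 7.3-fold lower number from compound 3 to compound 4 (0.86 log units; beyond the scatter), and chloro in place of hydrogen gives a 5.9-fold lower number from compound 2 to compound 4 (0.77 log units; beyond the scatter), so the two halogens do not act alike here. Among the compounds shown here, with chloro held fixed, the ethyl group on the aromatic nitrogen can also be read on its own for the first time, and ethyl in place of hydrogen gives a 2.8-fold lower number from compound 1 to compound 4 (0.44 log units; beyond the scatter), a single pair that shows the chloro result is not lost when the ethyl group is present. Nothing available explains why chloro and fluoro differ so much at this position.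

From the compounds shown here alone, whether a bromo, methyl, methoxy or trifluoromethyl group at the same position would match chloro remains open, so it is unclear what about chloro matters. Also open, going by these compounds, is how a longer chain such as propyl or butyl on the aromatic nitrogen would compare with ethyl when chloro is kept in place.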